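The source may hold more compounds than are shown below. What is called first, only, known or untested is meant among the compounds shown, and "the series" means these compounds.

Three compounds have been measured in a functional assay on HeLa cells (Homo sapiens) for antiproliferative activity, read by sulforhodamine B assay, with a stated time of 72 h; a lower number here means a stronger inhibitor, a higher number a weaker inhibitor:

Compound 1, `FC(F)(F)c1ccc(/C=C\c2cc3ccccc3nc2Cl)cc1`: 4220 nM
Compound 2, `COc1ccc2nc(Cl)c(/C=C\c3cccc(C(F)(F)F)c3)cc2c1`: 3030 nM
Compound 3, `COc1ccc2nc(Cl)c(/C=C\c3cc(C(F)(F)F)cc(C(F)(F)F)c3)cc2c1`: 4140 nM

Compounds 2 and 3 share one core and differ in a single spot: trifluoromethyl in place of hydrogen on an aromatic carbon. That change made a 1.4-fold higher number from compound 2 to compound 3 (0.14 log units; within the scatter), so the two values cannot be told apart. Compound 1 has a different core; how the two cores differ is not broken down here. Its value and those of compounds 2 and 3 all sit within the scatter of one another, so no order among the three can be claimed.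

Compound 4, `FC(F)(F)c1ccc(/C=C\c2cc3ccccc3nc2Cl)c(C(F)(F)F)c1`, is not yet measured. It comes from compound 1 by trifluoromethyl in place of hydrogen on an aromatic carbon. Within the data shown here, this is the same kind of change as the one from compound 2 to compound 3, but not the same: in compound 4 the entering group is ortho to a large group, whereas in compound 3 it is meta to a large group. Among the measured compounds shown here, the only guide is the step from compound 2 to compound 3, which was a 1.4-fold higher number from compound 2 to compound 3 (0.14 log units; within the scatter). On that basis compound 4 is expected to give a 1.3-fold higher number from compound 1 to compound 4 (0.12 log units; within the scatter) in this assay. The estimated value for compound 4 is 5500 nM, with a range from 2500 nM to 12000 nM.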

Compound 4, half-maximal inhibitory concentration: 35900 nM
For compound 4 the middle estimate is 6.5-fold (0.81 log units) below the measured one; the measured number lies above the stated range.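

In this assay, putting trifluoromethyl in place of hydrogen on compound 1 gave an 8.5-fold higher number from compound 1 to compound 4 (0.93 log units; beyond the scatter), so here the change clearly weakened the compound. The same change therefore did not carry over from one core to the other with the same size: the same change on two cores in this assay, a 1.4-fold higher number (0.14 log units; within the scatter) from compound 2 to compound 3 and an 8.5-fold higher number (0.93 log units; beyond the scatter) from compound 1 to compound 4, 6.2-fold (0.79 log units) apart, beyond the scatter of two such steps The two pairs differ both in their core and in where the new group enters, which in compound 4 is ortho to a large group; the data do not show which of these two differences matters, and two steps make no rule for the whole series.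

Among these compounds, it remains open whether trifluoromethyl at that same place on the core of compound 2 would produce a step like the one seen on compound 1. From the compounds shown here alone, it is also open whether a methyl group, a fluorine atom or an amine at that place would raise the number in the same way.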